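Amide to urea exchange on the shared core, growth inhibition

A few compounds are considered here, and "the series" means these few. Any claim that something is new, unique, unknown or untested is made for them only; others in the source may bear on it.

Compound 1 `COc1cc(-c2nn(-c3cccc(NC(=O)c4ccc(Cl)c(C(F)(F)F)c4)c3)cc2-c2ccncc2)ccc1Cl` is assessed in a functional assay on HOP-92 cells (Homo sapiens) for inhibition, read by sulforhodamine B assay, with a stated time of 48 h (a lower number here means a stronger inhibitor of growth, a higher number a weaker inhibitor of growth), where compound 1 gives 3230 nM. Among the compounds with values here, the only other measured analogue, compound 2 `O=C(Nc1cccc(-n2cc(-c3ccncc3)c(-c3ccc(Cl)c(O)c3)n2)c1)Nc1cc(C(F)(F)F)cc(C(F)(F)F)c1`, gives 1750 nM in this assay; compound 1 stands with compound 2, the two numbers within the scatter of each other. Compound 3 `COc1cc(-c2nn(-c3cccc(NC(=O)Nc4cccc(C(F)(F)F)c4)c3)cc2-c2ccncc2)ccc1Cl` is not yet measured. It differs from compound 1 as follows: (3-(trifluoromethyl)phenyl)amino in place of 4-chloro-3-(trifluoromethyl)phenyl on a carbonyl carbon. Within the data shown here, no measured pair shows this change, so the step from compound 1 to compound 3 is expected to be small, likely none beyond the scatter, perhaps a slightly lower number, a 1.3-fold lower number from compound 1 to compound 3 (0.11 log units; within the scatter). Compound 3 is therefore estimated at 2500 nM, in the range 1000 nM to 6500 nM.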

Compound 3, concentration for total growth inhibition: 1770 nM
Compound 3: middle estimate off by 1.4-fold (0.15 log units), on the high side; measured number inside the range.
By their numbers in this assay, from the lowest: compounds 2, 3 and 1 (each within the scatter of the next).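

In this assay the exchange on the carbonyl carbon gives a 1.8-fold lower number from compound 1 to compound 3 (0.26 log units; within the scatter) and so shows that (3-(trifluoromethyl)phenyl)amino can stand in place of 4-chloro-3-(trifluoromethyl)phenyl without a change beyond the scatter. The step brings in the nitrogen and removes the chlorine together, so neither can be read alone. No measured evidence bears on the cause of this result.

Open, as far as these compounds go, is how (4-chloro-3-(trifluoromethyl)phenyl)amino reads on the same carbonyl carbon, which would separate the two parts of the change. Also open, from the compounds shown here alone, is whether a carboxylic acid on that aromatic ring moves the number beyond the scatter.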